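The source may hold more compounds than are shown below. What is called first, only, known or untested is meant among the compounds shown, and "the series" means these compounds.

Measured compounds:
Compound 1, `CNCCN(C)c1nnnn1Cc1ccc(C#N)cc1`, gives 6% in an assay on cells for inhibition of protein arginine N-methyltransferase 1 (Homo sapiens), read by scintillation counting, with stated times of 15 min and 60 min, tested at 9 uM; a lower number here means less inhibition, a higher number more inhibition at the concentration tested (going by the name of the read-out).
Compound 2, `CNCCN(C)c1nnnn1Cc1ccc(OC)cc1`, gives 0% in this assay.
Compound 3, `COc1cccc(-c2ccc(CN(C)CCN)o2)c1`, gives 24% in this assay.

Compounds 1 and 2 share one core and differ by a single change, (cyano in place of methoxy on an aromatic carbon), which made a step of a number 6 percentage points higher from compound 2 to compound 1 (within the scatter). Compound 3 stands on a different core; how the two cores differ is not broken down here. Among the three measured compounds, compound 3 gives the highest number in this assay, and its gap to compound 1 and to compound 2 lies beyond the scatter.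

Compound 4, `CN(CCN)Cc1ccc(-c2cccc(C#N)c2)o1`, is not yet measured. It differs from compound 3 by cyano in place of methoxy on an aromatic carbon. This is the same kind of change as that from compound 2 to compound 1, but not the same: in compound 1 the cyano sits para to a large group, whereas in compound 4 it sits meta to a large group. Because the earlier step of a number 6 percentage points higher from compound 2 to compound 1 (within the scatter) was within the scatter, a similarly small step is expected, estimated as a number 4 percentage points higher from compound 3 to compound 4 (within the scatter). Compound 4 is therefore estimated at 28%, expected to lie between 10% and 45%.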

Compound 4, a percentage reported as inhibition, at one concentration (the size of the read-out at that concentration, not a potency): 38%
Beside the measured number, compound 4's estimate is 10 percentage points below it; the measured number falls inside the stated range.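

In this assay, replacing methoxy with cyano on the core of compound 3 gave a modest step, a number 14 percentage points higher from compound 3 to compound 4 (beyond the scatter). Set beside the earlier step, the change carries from one core to the other with no difference that can be told apart: the same change on two cores in this assay, a number 6 percentage points higher (within the scatter) from compound 2 to compound 1 and a number 14 percentage points higher (beyond the scatter) from compound 3 to compound 4, 8 percentage points apart, within the scatter of two such steps

Going by these compounds alone, this does not show that the change adds the same amount on every core, since only two cores are compared, only one of the two steps lies beyond the scatter, and the cyano does not stand in the same place relative to the large group in compound 1 and compound 4, so core and placement cannot be separated.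

The compounds shown leave open whether another group at this place, such as trifluoromethyl or a carboxylic acid, would follow the same course on either core. They also leave open whether a longer chain between the two amine nitrogens would alter the size of the step.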